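Furan-to-pyrrole swap on the saturated ring carbon

The compounds below may be only part of what the source reports. "The series", "measured", "known", "first", "only" and "open" are said of these compounds alone.

Three compounds of this series have been run in a functional assay on the whole organism (strain Wistar Albino) for inhibition, with Rattus norvegicus as the target, read by paw edema, with a stated time of 3 h, at a dose of 20 mg/kg; on this read-out higher numbers stand for more inhibition at the one dose given (going by the name of the read-out) and lower numbers for less inhibition. Compound 1 `COc1ccc(Cl)c(-c2nnc3sc(Cc4c(C)[nH]c5ccc(OC)cc45)nn23)c1` gives 26.1%. Compound 2 `COc1ccc(Cl)c(-c2nnc3n2NC(c2ccco2)S3)c1` gives 23.1%. Compound 3 `Cc1occc1-c1nnc2n1NC(c1ccc([N+](=O)[O-])o1)S2` gives 22.8%. On the raw numbers compound 2 holds the middle place of the three, but the gap to compound 3 and the gap to compound 1 are both within the usual scatter, so the three read as one level and no ranking can be drawn from them.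

Compound 4 `COc1ccc(Cl)c(-c2nnc3n2NC(c2ccc[nH]2)S3)c1` is the next member to be measured. It differs from compound 2 in one place: 1H-pyrrol-2-yl in place of furan-2-yl on a saturated ring carbon. The remainder of the molecule, the substituted aryl group on the fused core and the core itself, is unchanged.

Going by the values given here, no measured pair in the set shows this change, so its effect has to be guessed. Given that compound 2 gives 23.1% and that the whole set sits at one level, the step of a number 0.1 percentage points lower from compound 2 to compound 4 (within the scatter) is expected to stay within the scatter rather than move the number in either direction. Compound 4 is therefore estimated at 23%, with a range from 15% to 31%.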

Compound 4, a percentage reported as inhibition, in the whole organism at one dose (the size of the read-out at that dose, not a potency): 18.4%
The estimate for compound 4 lay 4.6 percentage points above the measured number; measured number inside the range.
By their numbers in this assay, from the lowest: compounds 4, 3, 2 and 1 (each within the scatter of the next).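

In this assay, going by these compounds alone, the replacement of furan-2-yl by 1H-pyrrol-2-yl on the saturated ring carbon provides the first comparison between compounds that differ in one place, and the result is a number 4.7 percentage points lower from compound 2 to compound 4 (within the scatter). At this position, trading the ring oxygen for a ring nitrogen, which by count brings in a hydrogen-bond donor and takes away a hydrogen-bond acceptor, therefore does not separate the two compounds on this read-out at the one dose given. No measurement in hand bears on the reason for the size of this step.

Within the data shown here, the comparison at this carbon covers only two five-membered aromatic rings with one hetero atom, so it remains open whether a phenyl ring, a short alkyl chain or an amine there would move the number beyond the scatter. Also open, going by these compounds, is whether the same swap would give a similar step with a different aryl group on the shared core, and a single-dose percentage cannot speak to potency.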